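A few compounds are considered here, and "the series" means these few. Any claim that something is new, unique, unknown or untested is made for them only; others in the source may bear on it.

Compound 2 `O=[N+]([O-])c1cn2c(n1)OCC(COc1ccc(OC(F)(F)F)cc1)C2` and compound 1 `COc1cc(-c2ccc(OC(F)(F)F)cc2)ccc1CO[C@@H]1COc2nc([N+](=O)[O-])cn2C1` share a core and differ in the aryl portion attached through the ether. In an ADME assay on Vero cells (Chlorocebus sabaeus) for cytotoxicity, with a stated time of 72 h (a lower number here means a stronger inhibitor, a higher number a weaker inhibitor), compound 1 gives > 128000 nM, which is a limit of the assay. In this assay compound 2 gives > 128000 nM, also a limit. Where compound 2 stands cannot be set in order, because of the limit of > 128000 nM in this assay, at which 2 of the 2 values shown sit. Compound 3 `O=[N+]([O-])c1cn2c(n1)OC[C@@H](COc1ccc(OC(F)(F)F)cc1)C2` is the next compound: the two compounds have the same atoms and bonds; at least one stereo element is drawn with a configuration in one of them and without one in the other: 1 of 1 stereo elements differ; a stereocentre at a saturated ring carbon is drawn without a configuration in compound 2 and R in compound 3. No step beyond the scatter is expected here; the step from compound 2 to compound 3 is estimated as a step that the limit leaves unreadable from compound 2 to compound 3. Compound 3 is therefore expected to give about 160000 nM, within 100000 nM to 300000 nM.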

Compound 3, half-maximal inhibitory concentration: > 128000 nM
Compound 3 was reported as a limit; the forecaster's own chance of this, stated with the estimate: 90%; the middle value lies beyond the limit too.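

For the compounds shown here, no step from compound 2 to compound 3 can be read in this assay, because both compounds are reported only as limits: the limit of > 128000 nM in this assay, at which 3 of the 3 values shown sit. The compounds shown leave open whether the drawn configuration of compound 3 changes cytotoxicity at all.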